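The source may report more compounds than this note shows. Statements on the series, on what has been measured and on what is new or still open speak of the compounds shown alone.

Measured in an ADME assay on LLC-MK2 cells (Macaca mulatta) for cytotoxicity, read by spectrophotometry and crystal violet staining, with a stated time of 4 days; a higher number here means that more compound is tolerated, a lower number that less compound is tolerated:
Compound 1 `CC(C)n1ncc2c(C(=O)Nc3ccc(F)cc3F)cc(-c3cccs3)nc21` gives > 200000 nM, a limit of the assay.
Compound 2 `CC(C)n1ncc2c(C(=O)Nc3c(F)cc(F)cc3F)cc(-c3cccs3)nc21` gives > 200000 nM, also a limit.
Compound 3 `CC(C)n1ncc2c(C(=O)Nc3cc(F)ccc3F)cc(-c3cccs3)nc21` gives 100000 nM.

For the measured compounds named here, compound 3 holds the only true number of the three, since the other two values are limits. Compound 4 `CC(C)n1ncc2c(C(=O)Nc3ccncn3)cc(-c3cccs3)nc21` departs from it as follows: pyrimidin-4-yl in place of 2,5-difluorophenyl on an amide-type nitrogen. Pyrimidin-4-yl thus takes the place of 2,5-difluorophenyl on an amide-type nitrogen. Changes on that nitrogen have so far given an at least 2.0-fold lower number from compound 1 to compound 3 (0.30 log units; that floor lies within the scatter) and an at least 2.0-fold lower number from compound 2 to compound 3 (0.30 log units; that floor lies within the scatter), while fluoro in place of hydrogen gave a step that the two limits leave unreadable from compound 1 to compound 2. Going by the values given here, no measured compound carries pyrimidin-4-yl, so the expectation rests on compound 3 at 100000 nM. No step beyond the scatter is expected in this assay, and the estimate is a 1.2-fold higher number from compound 3 to compound 4 (0.08 log units; within the scatter). Compound 4 is expected at 120000 nM, with an estimated range of 45000 nM to 200000 nM.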

Compound 4, half-maximal cytotoxic concentration: 50000 nM
For compound 4 the middle estimate is 2.4-fold (0.38 log units) above the measured one; measured number inside the range.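

Pyrimidin-4-yl on the amide-type nitrogen gives the only steps beyond the scatter in this assay, with an at least 4.0-fold lower number from compound 2 to compound 4 (0.60 log units; beyond the scatter) and an at least 4.0-fold lower number from compound 1 to compound 4 (0.60 log units; beyond the scatter) as its readings against the fluorinated phenyl groups. Against 2,5-difluorophenyl the same change stays within the scatter, with a 2.0-fold lower number from compound 3 to compound 4 (0.30 log units; within the scatter) as the one step that has true numbers at both ends. The other two steps are floors only, because their starting compounds sit at a limit: the limit of > 200000 nM in this assay, at which 2 of the 4 values shown sit.

The compounds shown do not separate the entry of the pyrimidin-4-yl ring from the loss of fluorine. From the compounds shown here alone, how an unsubstituted phenyl, or a phenyl carrying an amine or a carboxylic acid, would read on that nitrogen stays open.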